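From Phenyl to 3-Chloro-4-fluorophenyl on the Ring Nitrogen

A few compounds are considered here, and "the series" means these few. Any claim that something is new, unique, unknown or untested is made for them only; others in the source may bear on it.

Measured so far in a functional assay on DU-145 cells (Homo sapiens) for inhibition, read by MTT assay, with a stated time of 72 h; a higher number here means a weaker inhibitor, a lower number a stronger inhibitor:
Compound 1 `O=C1C=C(N2CCN(c3ccc(F)cc3)CC2)C(=O)c2ccccc21` gives 11700 nM.
Compound 2 `O=C1C=C(N2CCN(c3ccccc3)CC2)C(=O)c2ccccc21` gives 9900 nM.

Compound 2 stands at the lowest of the two numbers, with compound 1 as its nearest neighbour, and the step of a 1.2-fold lower number from compound 1 to compound 2 (0.07 log units; within the scatter) is within the scatter, so the two are not separated. Compound 3 `O=C1C=C(N2CCN(c3ccc(F)c(Cl)c3)CC2)C(=O)c2ccccc21` has not yet been measured. It differs from compound 2 by 3-chloro-4-fluorophenyl in place of phenyl on an amine nitrogen in a ring. For the measured compounds named here, the only measured step, a 1.2-fold lower number from compound 1 to compound 2 (0.07 log units; within the scatter), concerns the fluoro alone and bears on this change indirectly; no step covers the entering chloro. Since the fluoro made no difference beyond the scatter, compound 3 is expected to sit close to compound 2, with a 1.1-fold lower number from compound 2 to compound 3 (0.04 log units; within the scatter) no larger than the scatter in either direction. Compound 3 is thus estimated at 9000 nM, within 3000 nM to 27000 nM.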

Compound 3, half-maximal inhibitory concentration: 32200 nM
Compound 3: the middle estimate sits 3.6-fold (0.55 log units) below what was measured, outside the stated range (above it).
By their numbers in this assay, from the lowest: compounds 2 and 1 (each within the scatter of the next); then compound 3.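

In this assay the aromatic group on the amine nitrogen in the ring proves sensitive to substitution: 3-chloro-4-fluorophenyl in place of phenyl gives a 3.3-fold higher number from compound 2 to compound 3 (0.51 log units; beyond the scatter), whereas the fluoro alone gave only a 1.2-fold lower number from compound 1 to compound 2 (0.07 log units; within the scatter). The step that isolates the chloro on an aromatic carbon, a 2.8-fold higher number from compound 1 to compound 3 (0.44 log units; beyond the scatter), is itself beyond the scatter, so among these three compounds the weakening appears only once chloro is present. Nothing available here explains this shift.

The compounds shown leave open whether this weakening is particular to chloro or would also follow from a methyl, a methoxy or an amine on the same aromatic ring. They also leave open how a chloro would act on the phenyl ring without the fluoro, and whether a longer chain on the ring nitrogen would be tolerated.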